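Taking the tert-butoxy group off compound 3

This account rests on a few compounds, and the source may have more. Where it says the series, first, only, none or still open, it means among the compounds named here.

Measured so far in a functional assay on A549 cells (Homo sapiens) for inhibition, read by MTT assay, with a stated time of 72 h; on this read-out higher numbers stand for weaker inhibition and lower numbers for stronger inhibition
compound 1 `O=[N+]([O-])c1ccc(-c2nnc(SCCCN3CCN(c4nc5ccccc5o4)CC3)o2)cc1` gives 90800 nM
compound 2 `Cc1ccc(-c2nnc(SCCCN3CCN(c4nc5ccccc5o4)CC3)o2)cc1` gives 106000 nM
compound 3 `CC(C)(C)Oc1ccc(-c2nnc(SCCCN3CCN(c4nc5ccccc5o4)CC3)o2)cc1` gives 263000 nM

Compound 3 at 263000 nM stands highest of the three. Compound 4 `c1ccc(-c2nnc(SCCCN3CCN(c4nc5ccccc5o4)CC3)o2)cc1` has not been measured. It differs from compound 3 by hydrogen in place of tert-butoxy on an aromatic carbon with hydrogen in place of tert-butoxy on an aromatic carbon. Two modest steps bear on this, a 2.5-fold higher number from compound 2 to compound 3 (0.39 log units; beyond the scatter) and a 2.9-fold higher number from compound 1 to compound 3 (0.46 log units; beyond the scatter) and both bring tert-butoxy in. The third, a 1.2-fold higher number from compound 1 to compound 2 (0.07 log units; within the scatter) shows that methyl and nitro do not separate. Within the data shown here, no measured compound has hydrogen at that place, so the comparison is indirect. In this assay a modest fall of similar size is therefore expected, estimated as a 2.2-fold lower number from compound 3 to compound 4 (0.34 log units; beyond the scatter) and no larger. Compound 4 is estimated at 120000 nM with an expected range from 60000 nM to 250000 nM on this read-out.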

Compound 4, half-maximal inhibitory concentration: 108000 nM
Compound 4: the middle estimate sits 1.1-fold (0.05 log units) above what was measured; low and high end bracket the measured number.
By their numbers in this assay, from the lowest: compounds 1, 2 and 4 (each within the scatter of the next); then compound 3.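

In this assay, among these compounds, the step of a 2.4-fold lower number from compound 3 to compound 4 (0.39 log units; beyond the scatter) shows that the phenyl without a substituent sits with the methyl and nitro compounds, leaving tert-butoxy as the only group here that stands apart. Hydrogen does not separate from either of the other two groups, as the steps of a 1.0-fold higher number from compound 2 to compound 4 (0.01 log units; within the scatter) and a 1.2-fold higher number from compound 1 to compound 4 (0.08 log units; within the scatter) are both small. No measurement shown here explains the difference seen with tert-butoxy. Going by these compounds, what remains open is whether an amine, a carboxylic acid or a longer alkoxy chain at this place would leave the number unchanged or move it in either direction.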